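Aryl sulfonate series: one-carbon extension of the urea chain

The source may hold more compounds than are shown below. What is called first, only, known or untested is meant among the compounds shown, and "the series" means these compounds.

Measured so far, in a functional assay on MCF7 cells (Homo sapiens) for antiproliferative activity, read by sulforhodamine B assay, with a stated time of 48 h; a higher number here means a weaker inhibitor, a lower number a stronger inhibitor:
compound 1, `CCC(=O)Nc1ccc(S(=O)(=O)Oc2ccccc2C(C)C)cc1`: compound 1 gives 11000 nM
compound 2, `CC(C)C(=O)Nc1ccc(S(=O)(=O)Oc2ccccc2C(C)C)cc1`: compound 2 gives 8600 nM
compound 3, `CCNC(=O)Nc1ccc(S(=O)(=O)Oc2ccccc2C(C)C)cc1`: compound 3 gives 10000 nM

The three numbers sit close together. The steps of a 1.3-fold lower number from compound 1 to compound 2 (0.11 log units; within the scatter), a 1.1-fold lower number from compound 1 to compound 3 (0.04 log units; within the scatter) and a 1.2-fold higher number from compound 2 to compound 3 (0.07 log units; within the scatter) all lie within the scatter, so no order among compound 1, compound 2 and compound 3 can be read from them.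

Compound 4, `CCCNC(=O)Nc1ccc(S(=O)(=O)Oc2ccccc2C(C)C)cc1`, is not yet measured. It differs from compound 3 by methyl in place of hydrogen on a saturated chain carbon, two bonds along the chain from an amide-type nitrogen. The same kind of change separates compound 1 from compound 2, namely (methyl in place of hydrogen on a saturated chain carbon bound to a carbonyl carbon and a saturated chain carbon), and there it gave a 1.3-fold lower number from compound 1 to compound 2 (0.11 log units; within the scatter). The two cores differ by ethylamino in place of ethyl on a carbonyl carbon. The place is not the same: in compound 1 it is a saturated chain carbon bound to a carbonyl carbon and a saturated chain carbon, in compound 3 a saturated chain carbon two bonds along the chain from an amide-type nitrogen. So the change is of the same kind, not the same.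

The expected step for compound 4 is a 1.1-fold lower number from compound 3 to compound 4 (0.05 log units; within the scatter), resting on compound 1 to compound 2 giving a 1.3-fold lower number from compound 1 to compound 2 (0.11 log units; within the scatter). Compound 4 is estimated at 9000 nM, expected between 4500 nM and 18000 nM.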

Compound 4, half-maximal inhibitory concentration: 2700 nM
Compound 4: the middle estimate sits 3.3-fold (0.52 log units) above what was measured, outside the stated range (below it).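

In this assay the same kind of change does not carry over at the same size from one core to the other: the same change on two cores in this assay, a 1.3-fold lower number (0.11 log units; within the scatter) from compound 1 to compound 2 and a 3.7-fold lower number (0.57 log units; beyond the scatter) from compound 3 to compound 4, 2.9-fold (0.46 log units) apart, beyond the scatter of two such steps On the core of compound 3 the added methyl gives a 3.7-fold lower number from compound 3 to compound 4 (0.57 log units; beyond the scatter), and the propylamino group also sets compound 4 apart from both carbonyl neighbours with an ethyl or isopropyl group, through a 3.2-fold lower number from compound 2 to compound 4 (0.50 log units; beyond the scatter) and a 4.1-fold lower number from compound 1 to compound 4 (0.61 log units; beyond the scatter). This rests on one pair per core, and the methyl sits at a different place in each pair, so the role of the core cannot be separated from that of the place, and no general rule for transferring this change in the series follows.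

The compounds shown leave open whether a butylamino chain on the carbonyl carbon would give a still lower number or whether the gain ends at propylamino. An isopropylamino group there would also remain to be compared, as it would put a branched chain on the core of compound 3.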